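Fluoro for methoxy on the triazole aryl group

A few compounds are considered here, and "the series" means these few. Any claim that something is new, unique, unknown or untested is made for them only; others in the source may bear on it.

Three compounds share one core. Compound 1 `C=C1C(=O)[C@]23C[C@@]1(O)CC[C@H]2c1ccc(OS(=O)(=O)c2ccc(C)cc2)c(C)c1[C@@H]3Cn1cc(-c2ccc(Br)cc2)nn1` carries a carbonyl and a 4-bromophenyl group; in a functional assay on MCF7 cells (Homo sapiens) for cytotoxicity, read by MTT assay, with a stated time of 4 days (on this read-out lower numbers stand for stronger inhibition and higher numbers for weaker inhibition), compound 1 gives 250 nM. Compound 2 `C=C1C[C@]23C[C@@]1(O)CC[C@H]2c1ccc(OS(=O)(=O)c2ccc(C)cc2)c(C)c1[C@@H]3Cn1cc(-c2ccc(OC)cc2)nn1` has a methylene in place of that carbonyl and a 4-methoxyphenyl group. In this assay compound 2 reaches only a limit of the assay, > 20000 nM. Compound 2 thus sits at the limit of > 20000 nM in this assay, at which 1 of the 2 values shown sits, and it differs from compound 1 in two places, so the two values can only be set side by side, not read as one step. Compound 3 `C=C1C[C@]23C[C@@]1(O)CC[C@H]2c1ccc(OS(=O)(=O)c2ccc(C)cc2)c(C)c1[C@@H]3Cn1cc(-c2ccc(F)cc2)nn1` keeps the core of compound 2 and changes one place: fluoro in place of methoxy on an aromatic carbon. With compound 2 known only as a limit, the size of the step to compound 3 is open; a move back into measurable range is expected, but its extent is uncertain and a further limit remains possible. The estimated step is an at least 2.5-fold lower number from compound 2 to compound 3 (0.39 log units; beyond the scatter). In this assay compound 3 is expected to give about 8000 nM, between 1500 nM and 30000 nM.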

Compound 3, half-maximal inhibitory concentration: > 20000 nM
Compound 3 ended at the assay's limit (the forecaster's own chance of this, stated with the estimate: 40%); at least 2.5-fold (0.39 log units) between middle value and limit.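

Compound 2 and compound 3 both sit at a limit of this assay, so no step between them can be read: the limit of > 20000 nM in this assay, at which 2 of the 3 values shown sit.

The compounds shown leave open how much, if at all, fluoro in place of methoxy on an aromatic carbon changes the value in this assay.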